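Swapping the Benzyl Substituent in a Potent Receptor Binder

The source may report more compounds than this note shows. Statements on the series, on what has been measured and on what is new or still open speak of the compounds shown alone.

Compound 2 `CCN(Cc1ccccc1C)c1cc(C)nc2c(-c3cnc(N(C)C)cc3C)c(C)nn12` and compound 1 `CCCN(CC1CC1)c1cc(C)nc2c(-c3cnc(N(C)C)cc3C)c(C)nn12` share one core and differ in the group on the chain nitrogen. In an assay on CHO cells for binding affinity to corticotropin-releasing factor receptor 1 (Homo sapiens) (a lower number here means a stronger inhibitor, a higher number a weaker inhibitor), compound 2 gives 2.4 nM and compound 1 gives 2.6 nM; the two numbers lie within the scatter of each other, so neither can be called the stronger binder. Compound 3 `CCN(Cc1ccc(Cl)cc1)c1cc(C)nc2c(-c3cnc(N(C)C)cc3C)c(C)nn12` carries 4-chlorophenyl in place of 2-methylphenyl on a saturated chain carbon bound to a nitrogen on an aromatic ring. Going by the values given here, no measured pair shows this change, so a step of modest size is expected, slightly toward weaker binding, with the step from compound 2 to compound 3 of a 1.7-fold higher number from compound 2 to compound 3 (0.22 log units; within the scatter) in this assay. Compound 3 is expected to give 4 nM, within 1.5 nM to 12 nM.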

Compound 3, inhibition constant: 1.3 nM
For compound 3 the middle estimate is 3.1-fold (0.49 log units) above the measured one; the whole stated range lies above it.
By their numbers in this assay, from the lowest: compounds 3, 2 and 1 (each within the scatter of the next).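

In this assay, replacing 2-methylphenyl with 4-chlorophenyl on a saturated chain carbon bound to a nitrogen on an aromatic ring gives a 1.8-fold lower number from compound 2 to compound 3 (0.27 log units; within the scatter). This place therefore tolerates both substituted phenyl rings without a change that can be told from the scatter. No available measurement explains this result.

The change swaps both the substituent and its place on the ring, and a 2-chlorophenyl group would be needed to separate the two. As far as these compounds go, how this site responds to a pyridine ring or a carboxylic acid also remains open.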